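This account rests on a few compounds, and the source may have more. Where it says the series, first, only, none or still open, it means among the compounds named here.

Measured compounds:
- Compound 1 `COc1cc2cc(Oc3ccc(NC(=O)Nc4ccc(C(F)(F)F)cc4)cc3)c(C)nc2cc1OC`: 82.9%
- Compound 2 `COc1cc2cc(Oc3ccc(NC(=O)Nc4ccc(Cl)c(C(F)(F)F)c4)cc3)c(C)nc2cc1OC`: -23%

In a functional assay on Malme-3M cells (Homo sapiens) for inhibition, read by sulforhodamine B assay, with a stated time of 48 h, tested at 10 uM (on this read-out higher numbers stand for a weaker effect at the one concentration tested and lower numbers for a stronger effect), compound 1 gives 82.9%, the higher of the two numbers, so it shows the weaker effect of the pair. Compound 2 gives -23%. Going by the values given here, the only measured step, a number 105.9 percentage points lower from compound 1 to compound 2 (beyond the scatter), replaces 4-(trifluoromethyl)phenyl with 4-chloro-3-(trifluoromethyl)phenyl on an amide-type nitrogen and is a large drop.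

Compound 3 `COc1cc2cc(Oc3ccc(NC(=O)Nc4ccc(Cl)c(Cl)c4)cc3)c(C)nc2cc1OC` has not yet been measured. It differs from compound 1 by 3,4-dichlorophenyl in place of 4-(trifluoromethyl)phenyl on an amide-type nitrogen. Among the compounds with values here, this change resembles the one from compound 1 to compound 2, since both put a chlorine-bearing ring in place of the 4-(trifluoromethyl)phenyl ring, and the measured step was large and downward. A similar large downward step is therefore expected, although the data do not show whether a second chlorine behaves like a trifluoromethyl group. Compound 3 is estimated at 5%, between -30% and 45%, which means an expected step of a number 77.9 percentage points lower from compound 1 to compound 3 (beyond the scatter).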

Compound 3, a percentage reported as activity, at one concentration (the size of the read-out at that concentration, not a potency): 14.9%
For compound 3 the middle estimate is 9.9 percentage points below the measured one; the measured number falls inside the stated range.
By their numbers in this assay, from the lowest: compound 2; then compound 3; then compound 1.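

In this assay the ring on the amide-type nitrogen again has a strong influence: putting 3,4-dichlorophenyl in place of 4-(trifluoromethyl)phenyl gives a number 68 percentage points lower from compound 1 to compound 3 (beyond the scatter) and shows that a large fall does not require a trifluoromethyl group on the ring. Compound 2 and compound 3 also form a new pair that differs at a single ring carbon. Chloro in place of trifluoromethyl there gives a number 37.9 percentage points higher from compound 2 to compound 3 (beyond the scatter) and shows that the group at this carbon still matters when the ring already carries a chlorine.

The compounds shown leave open whether a single chlorine alone would suffice and how rings bearing a methoxy group, a nitrile or an amine would compare. No supporting evidence is available to explain either step.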